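From dimethylcarbamoyl to 1H-imidazol-2-yl: expected clearance of compound 4

The source may report more compounds than this note shows. Statements on the series, on what has been measured and on what is new or still open speak of the compounds shown alone.

Compound 1 `CC(=O)c1cccc([C@@H](O)[C@H](O)[C@H](O)CO)n1`: 14 mL/min/kg
Compound 2 `CC(=O)c1nc([C@@H](O)[C@H](O)[C@H](O)CO)cn1C`: 5.7 mL/min/kg
Compound 3 `CN(C)C(=O)c1nc([C@@H](O)[C@H](O)[C@H](O)CO)c[nH]1`: 11.3 mL/min/kg

In an in vivo ADME assay on the whole organism (strain 129/SvEvBrd x C57BL/6) for pharmacokinetics, with Mus musculus as the target, at a dose of 1 mg/kg by the intravenous route (a higher number here means faster removal of the compound, a lower number slower removal), compound 3 gives 11.3 mL/min/kg, the middle of the three numbers and within the scatter of both compound 1 and compound 2. In compound 4 `OC[C@@H](O)[C@@H](O)[C@H](O)c1c[nH]c(-c2ncc[nH]2)n1`, 1H-imidazol-2-yl stands in place of dimethylcarbamoyl on an aromatic carbon (1H-imidazol-2-yl in place of dimethylcarbamoyl on an aromatic carbon). Among the measured compounds shown here, no measured pair shows a change of this kind, so the data give no direct size for it, and no step beyond the scatter is expected in this assay. The expected change is a 1.1-fold lower number from compound 3 to compound 4 (0.05 log units; within the scatter). For compound 4 the estimated clearance is 10 mL/min/kg, with an expected range of 4 mL/min/kg to 25 mL/min/kg.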

Compound 4, clearance: 31.5 mL/min/kg
Estimate against measurement, compound 4: 3.2-fold (0.50 log units) below; the whole stated range lies below it.
By their numbers in this assay, from the lowest: compounds 2, 3 and 1 (each within the scatter of the next, the first and the last beyond it); then compound 4.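

In this assay, the aromatic carbon between two ring nitrogen atoms proves sensitive to the group it carries: 1H-imidazol-2-yl in place of dimethylcarbamoyl gives a 2.8-fold higher number from compound 3 to compound 4 (0.45 log units; beyond the scatter). This happens although both groups have 5 heavy atoms, so that count alone does not fix the clearance here. No measurement at hand accounts for the step.

The compounds shown leave open whether the entering ring or its hydrogen-bond donor goes with the step. A methyl on the ring nitrogen of that imidazole, or a carboxylic acid at this carbon, would bear on that.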